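This account rests on a few compounds, and the source may have more. Where it says the series, first, only, none or still open, it means among the compounds named here.

Measured compounds:
- compound 1, `CCCCCCc1ccc(C(=O)CCN(CCCC)CCCC)cc1`, in an assay on isolated protein for displacement of a labelled ligand from thyroid hormone receptor alpha (Homo sapiens), read by fluorescence polarization; on this read-out lower numbers stand for stronger inhibition and higher numbers for weaker inhibition: 6900 nM
- compound 2, `C/C=C/C(=O)c1ccc(CCCCCCC)cc1`, in this assay: 18900 nM
- compound 3, `C=CC(=O)c1ccc(CCC)cc1`, in this assay: > 100000 nM

Compound 3 returns no number in this assay but only a limit, > 100000 nM. Of the three values shown, it is the one that sits at the limit of > 100000 nM in this assay, at which 1 of the 3 values shown sits. Compound 1 and compound 2 both carry a long straight alkyl chain on the aromatic ring and both give a measurable value in this assay; compound 3 carries the short propyl chain and does not.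

Compound 4, `C=CC(=O)c1ccc(CC(C)(C)C)cc1`, has not yet been run in this assay. It differs from compound 3 in one place: tert-butyl in place of ethyl on a saturated chain carbon bound to an aromatic carbon. Read one bond further out, the change is propyl to neopentyl, so the chain on the aromatic ring grows by two carbons and becomes branched at its end, while the acryloyl side stays as in compound 3.

Within the data shown here, no step between measured compounds is available to calibrate this change. Because compound 3 itself is at the limit of > 100000 nM in this assay, at which 1 of the 3 values shown sits, the step of a number no higher from compound 3 to compound 4 (the limit leaves the size open) is expected to be small and most likely to leave compound 4 at the same limit. The estimate for compound 4 in this assay is 100000 nM, with a range from 30000 nM to 300000 nM, and the assay is expected more often than not to report only a limit for compound 4.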

Compound 4, half-maximal inhibitory concentration: 69600 nM
Beside the measured number, compound 4's estimate is 1.4-fold (0.16 log units) above it; low and high end bracket the measured number.
By their numbers in this assay, from the lowest: compound 1; then compound 2; then compound 4. At a limit, above all of these: compound 3.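

In this assay compound 4 gives a real number, 69600 nM, so with the acryloyl side unchanged, neopentyl in place of propyl yields a reading on the measurable scale. Compound 3 stays a limit and not a number: the limit of > 100000 nM in this assay, at which 1 of the 4 values shown sits.

The change of tert-butyl in place of ethyl on a saturated chain carbon bound to an aromatic carbon therefore reads as an at least 1.4-fold lower number from compound 3 to compound 4 (0.15 log units; that floor lies within the scatter), which fixes only a floor, and the true size of the step may be larger than that floor but cannot be read from this pair.

The compounds shown do not separate the added chain length from the branching at the chain end, and a straight pentyl chain on the same acryloyl compound would be the pair that tells the two apart. Also open, going by these compounds, is how this position responds to a longer chain, or to an amine or a carboxylic acid at the chain end, with the acryloyl side held constant.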